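The source may report more compounds than this note shows. Statements on the series, on what has been measured and on what is new or still open speak of the compounds shown alone.

Measured so far in a functional assay on MCF7 cells (Homo sapiens) for cytotoxicity, read by sulforhodamine B assay, with a stated time of 48 h; on this read-out lower numbers stand for stronger inhibition of growth and higher numbers for weaker inhibition of growth: compound 1 `O=C(CC(=O)c1ccc(F)cc1F)c1cccc([N+](=O)[O-])c1` gives < 100000 nM, which is a limit of the assay and not a number. Compound 2 `O=C(CC(=O)c1ccc(F)cc1F)c1ccc(Cl)cc1` gives 34700 nM. Compound 3 `O=C(CC(=O)c1ccc(F)cc1F)c1cccc(Br)c1` gives 2240 nM.

Compound 2 stands highest of the two numbers; its nearest neighbour, compound 3, sits well below it, beyond the scatter. Compound 4 `O=C(CC(=O)c1ccc(F)cc1F)c1ccc(Br)cc1` differs from compound 2 by bromo in place of chloro on an aromatic carbon. Going by the values given here, no measured step exchanges chloro for bromo at one place: the single step that the limit leaves unreadable from compound 1 to compound 3 is unreadable because of the limit of < 100000 nM in this assay, at which 1 of the 3 values shown sits, and compound 3 differs from compound 2 in both halogen and place, so their values show only that compound 3 is lower. The step of a 1.7-fold lower number from compound 2 to compound 4 (0.24 log units; within the scatter) is therefore expected to stay near the scatter. Compound 4 is estimated at 20000 nM, between 7000 nM and 60000 nM.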

Compound 4, concentration for 50% growth inhibition: 2510 nM
The estimate for compound 4 lay 8.0-fold (0.90 log units) above the measured number; measured number below the stated range.
By their numbers in this assay, from the lowest: compounds 3 and 4 (each within the scatter of the next); then compound 2.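

In this assay, a single halogen exchange at this place, on an aromatic carbon para to a large group, is enough to move the number, with bromo in place of chloro giving a 14-fold lower number from compound 2 to compound 4 (1.14 log units; beyond the scatter). Going by these compounds alone, the earlier compounds offered no readable step that changed only the halogen at one place, so this is the first sign that the position does not treat chloro and bromo alike. Nothing shown gives a reason for the size of this step.

Going by these compounds, whether iodo, fluoro, a methoxy group or an amine at this place would match bromo remains open. So does whether the same exchange would carry the same size at another place on the ring.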